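The source may hold more compounds than are shown below. What is called first, only, known or untested is meant among the compounds shown, and "the series" means these compounds.

Measured so far:
compound 1 `CCCN(CCC)c1ccc(C)c2nc(-c3c(OC)cc(COC)cc3OC)c(C)cc12` — 88 nM
compound 2 `COCc1cc(OC)c(-c2nc3c(C)ccc(N(C)C)c3cc2C)c(OC)c1` — 212 nM

Both values come from an assay on HEK293 cells for displacement of a labelled ligand from corticotropin-releasing factor receptor 1 (Homo sapiens), with a stated time of 2 h; on this read-out higher numbers stand for weaker inhibition and lower numbers for stronger inhibition. Among the compounds with values here, compound 2 holds the higher of the two numbers; the only measured step, a 2.4-fold higher number from compound 1 to compound 2 (0.38 log units; beyond the scatter), separates it from compound 1. Compound 3 `COCc1cc(OC)c(-c2nc3c(C)ccc(N(CC4CC4)CC4CC4)c3cc2C)c(OC)c1` has not been measured. Against compound 2 the change is bis(cyclopropylmethyl)amino in place of dimethylamino on an aromatic carbon. Within the data shown here, the single step that bears on this is the one from dipropylamino to dimethylamino, where a 2.4-fold higher number from compound 1 to compound 2 (0.38 log units; beyond the scatter) was seen; compound 3 moves from dimethylamino back to a larger dialkylamino group, so a step of comparable size in the opposite direction in this assay is expected, roughly returning to the region of compound 1. Among the measured compounds shown here, no measured pair probes the two three-membered rings themselves, so the range is kept wide. Compound 3 is expected to give 80 nM (range 30 nM to 250 nM), corresponding to an expected step of a 2.7-fold lower number from compound 2 to compound 3 (0.42 log units; beyond the scatter).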

Compound 3, half-maximal inhibitory concentration: 88 nM
Beside the measured number, compound 3's estimate is 1.1-fold (0.04 log units) below it, and the stated range covers the measured number.
By their numbers in this assay, from the lowest: compounds 1 and 3 (each within the scatter of the next); then compound 2.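

In this assay, within the data shown here, bis(cyclopropylmethyl)amino in place of dimethylamino gives a 2.4-fold lower number from compound 2 to compound 3 (0.38 log units; beyond the scatter) on this aromatic carbon, so dipropylamino is no longer the only dialkylamino group separated from dimethylamino by a step beyond the scatter. Against dipropylamino, the same group gives no change at the digits printed from compound 1 to compound 3 (within the scatter), so the two three-membered rings of carbon only leave the number where the open propyl chains put it, and compound 1 and compound 3 cannot be ordered. No evidence on hand accounts for either step.

Among these compounds, only three amino groups are compared at this position, so a monoalkylamino group, a morpholine ring or longer dibutylamino chains remain open. Also open, from the compounds shown here alone, is whether these steps hold when the methoxymethyl group of the shared core is replaced by a different group.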